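Capping a Hydroxy Group with Ethyl

The compounds below may be only part of what the source reports. "The series", "measured", "known", "first", "only" and "open" are said of these compounds alone.

Of the compounds shown here, three that share one core have been tested in a functional assay on RAW264.7 cells (Mus musculus) for inhibition, read by ELISA, with stated times of 1 h and 18 h, tested at 1 uM; on this read-out higher numbers stand for a weaker effect at the one concentration tested and lower numbers for a stronger effect. Compound 1 `C=C1CC[C@H]2C(C)(C)CCC[C@]2(C)[C@H]1C/C=C1/C(=O)OC[C@H]1O` gives 68.1%. Compound 2 `C=C1CC[C@H]2C(C)(C)CCC[C@]2(C)[C@H]1C[C@@H](O)C1=CCOC1=O` gives 84%. Compound 3 `C=C1CC[C@H]2C(C)(C)CCC[C@]2(C)[C@H]1C/C=C1\CC(O)OC1=O` gives 82.4%. On these numbers compound 3 holds the second highest of the three values; its value and that of compound 2 lie within the scatter of each other, so no order between them can be read, while compound 1 sits lower by a margin beyond the scatter, which means compound 1 shows the stronger effect at the single concentration tested.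

Compound 4 `C=C1CC[C@H]2C(C)(C)CCC[C@]2(C)[C@H]1C/C=C1\CC(OCC)OC1=O` has not yet been measured in this assay. It differs from compound 3 in one place: ethyl in place of hydrogen on an oxygen on a saturated carbon. Among the measured compounds shown here, no pair of measured compounds shows the effect of this change, so nothing in these data says how this assay responds to it. The change is small and leaves the core untouched; the step from compound 3 to compound 4 is therefore expected to be small, in no fixed direction, and probably within the scatter. Compound 4 is expected to give about 80%, within a range from 64% to 96%. This estimate corresponds to an expected step of a number 2.4 percentage points lower from compound 3 to compound 4 (within the scatter).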

Compound 4, a percentage reported as activity, at one concentration (the size of the read-out at that concentration, not a potency): 100%
Compound 4: middle estimate off by 20 percentage points, on the low side, outside the stated range (above it).
By their numbers in this assay, from the lowest: compound 1; then compounds 3 and 2 (each within the scatter of the next); then compound 4.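

Among the compounds shown here, replacing hydroxy with ethoxy is the first single change that can be read in this assay, and it is not a neutral swap: the result is a number 17.6 percentage points higher from compound 3 to compound 4 (beyond the scatter). On this read-out, that means capping the hydroxy group with ethyl weakens the effect at the one concentration tested, so this oxygen on a saturated carbon is a place where a small change can shift the read-out beyond the usual scatter. Nothing available explains this step, and a single pair cannot show whether it comes from losing the hydrogen or from adding the ethyl.

On these data alone, whether a methoxy group, a longer chain such as propoxy, or an amine at this place would behave like the hydroxy group of compound 3 or like the ethoxy group of compound 4 remains open. As far as these compounds go, it is also open whether the same capping would produce a similar step on the hydroxy groups of compound 1 and compound 2, where the hydroxy group sits elsewhere on the molecule.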